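The source may hold more compounds than are shown below. What is called first, only, known or untested is meant among the compounds shown, and "the series" means these compounds.

Measured compounds:

Compound 1, `COc1cc(C(=O)NCc2cccc(Cl)c2)cc2nn(CCn3cccn3)cc12`: in an assay on isolated protein for inhibition of thyroid hormone receptor beta (Homo sapiens), read by fluorescence, with a stated time of 30 min (a lower number here means a stronger inhibitor, a higher number a weaker inhibitor), compound 1 gives 464 nM.
Compound 2, `COc1cc(C(=O)N2CCCC2(C)C)cc2nc(NCc3cccc(Cl)c3)oc12`: in this assay compound 2 gives 47 nM.

Of the two numbers shown, compound 2 has the lower one, and the gap to compound 1 lies beyond the usual scatter of repeated measurements. The two compounds differ in several places at once, so no single structural change can be tied to that gap; the values only show that compound 2 is the stronger inhibitor of the pair.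

Compound 3, `COc1cc(C(=O)N2CCC(O)CC2)cc2nc(NCc3cccc(Cl)c3)oc12`, is not yet measured. It differs from compound 2 in one place: 4-hydroxypiperidin-1-yl in place of 2,2-dimethylpyrrolidin-1-yl on a carbonyl carbon. One amide substituent is thus exchanged for another of the same heavy-atom count, but of a different ring size and with a hydrogen-bond donor and acceptor that the leaving group lacks. For the measured compounds named here, no measured pair shows the effect of such a change here, so the expectation rests on the general size of substituent swaps on this amide.

For compound 3 in this assay the estimate is 150 nM, with a likely range from 40 nM to 600 nM. This estimate corresponds to an expected step of a 3.2-fold higher number from compound 2 to compound 3 (0.50 log units; beyond the scatter), a modest weakening that may or may not exceed the scatter.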

Compound 3, half-maximal inhibitory concentration: 352 nM
Compound 3: the middle estimate sits 2.3-fold (0.37 log units) below what was measured; the range from low to high includes it.
By their numbers in this assay, from the lowest: compound 2; then compounds 3 and 1 (each within the scatter of the next).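

In this assay the exchange of 2,2-dimethylpyrrolidin-1-yl for 4-hydroxypiperidin-1-yl on a carbonyl carbon gives a 7.5-fold higher number from compound 2 to compound 3 (0.87 log units; beyond the scatter) and so shows, in a way the earlier pair could not, that the group on this amide affects the number when the rest of the molecule stays the same. The two groups have the same heavy-atom count, so this step shows that matching that count does not keep the number within the scatter, although the change is still described as modest. Ring size, the two methyl groups and the hydroxyl all change together in this one step, and no separate measurement here bears on what lies behind it.

The compounds shown leave open which of those differences accounts for the step, and whether any of them acts alone. Plain piperidin-1-yl would separate the ring size from the hydroxyl, while unsubstituted pyrrolidin-1-yl would do the same for the two methyl groups, and 4-methoxypiperidin-1-yl would test the hydroxyl hydrogen.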